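The compounds below may be only part of what the source reports. "The series", "measured", "known", "first", "only" and "open" are said of these compounds alone.

The series shares one core and is followed in a functional assay on Vero cells (Chlorocebus sabaeus) for cytotoxicity; a higher number here means that more compound is tolerated, a lower number that less compound is tolerated. Compound 1 `O=c1[nH]c(=O)n(COC(CO)CO)cc1[N+](=O)[O-]` carries a nitro group on an aromatic carbon. In this assay compound 1 reaches only a limit, > 383000 nM. Compound 2 `O=c1[nH]c(=O)n(COC(CO)CO)cc1CO` carries hydroxymethyl in its place. In this assay compound 2 likewise reaches only a limit, > 406000 nM. The step that the two limits leave unreadable from compound 1 to compound 2 therefore cannot be read in size. Going by the values given here, compound 2 thus stands on a limit, and the only further value shown is a limit as well, as the limit of > 383000 nM in this assay, at which 1 of the 2 values shown sits, and the limit of > 406000 nM in this assay, at which 1 of the 2 values shown sits, record.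

Compound 3 `O=c1[nH]c(=O)n(COC(CO)CO)cc1/C=C/Br` has not yet been measured. It differs from compound 2 by 2-bromoethenyl in place of hydroxymethyl on an aromatic carbon. Among the compounds with values here, the single measured step, a step that the two limits leave unreadable from compound 1 to compound 2, is the only one that bears on this change, and it yields no readable size, so no step beyond the scatter can be derived for this assay. Compound 3 is expected to give a step of an at least 1.3-fold lower number from compound 2 to compound 3 (0.13 log units; that floor lies within the scatter) that stays within the scatter. Compound 3 is therefore estimated at 300000 nM, with a range from 100000 nM to 500000 nM, most likely again as a limit.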

Compound 3, half-maximal cytotoxic concentration: > 311000 nM
Compound 3: only a limit was reported; the forecaster's own chance of this, stated with the estimate: 70%; middle value at least 1.0-fold (0.01 log units) from the limit.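

In this assay compound 3 also reaches only a limit, > 311000 nM. The steps from compound 2 to compound 3 and from compound 1 to compound 3 therefore cannot be read in size. The compounds shown leave open what number any of them would give in this assay, and whether exchanging the group on the aromatic carbon shifts that number at all.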